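Methyl added to compound 3: expected effect on antiproliferative activity

This account rests on a few compounds, and the source may have more. Where it says the series, first, only, none or still open, it means among the compounds named here.

Measured so far in a functional assay on HCT-116 cells (Homo sapiens) for antiproliferative activity, with a stated time of 4 h; on this read-out higher numbers stand for weaker inhibition and lower numbers for stronger inhibition
- compound 1 `O=C1NC(=O)c2c1c1c(c3[nH]c4ccccc4c23)C(=O)CCC1` gives 1100 nM
- compound 2 `O=C1NC(=O)c2c1c1c(O)cccc1c1[nH]c3ccccc3c21` gives 17500 nM
- compound 3 `O=c1ccc(=O)c2c1c1[nH]c3ccccc3c1c1c(=O)[nH]c(=O)c21` gives 5300 nM

Compound 3 holds the second highest of the three numbers, with clear gaps beyond the scatter to compound 2 on the higher side and compound 1 on the lower side. Compound 4 `Cc1ccc2[nH]c3c4c(=O)ccc(=O)c4c4c(=O)[nH]c(=O)c4c3c2c1` differs from compound 3 by methyl in place of hydrogen on an aromatic carbon. Among the measured compounds shown here, no measured pair isolates this change, so in this assay no step beyond the scatter is expected, and neither direction is favoured. The estimated step is a 1.2-fold lower number from compound 3 to compound 4 (0.07 log units; within the scatter). For compound 4 the estimated value is 4500 nM, with an expected range from 1600 nM to 13000 nM.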

Compound 4, half-maximal inhibitory concentration: 700 nM
For compound 4 the middle estimate is 6.4-fold (0.81 log units) above the measured one; measured number outside the range, below it.
By their numbers in this assay, from the lowest: compounds 4 and 1 (each within the scatter of the next); then compound 3; then compound 2.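

In this assay, methyl in place of hydrogen on an aromatic carbon gives a 7.6-fold lower number from compound 3 to compound 4 (0.88 log units; beyond the scatter). Among the compounds shown here, this is the first one-place pair, and it shows that this position, meta to a fused ring and para to a fused ring, is sensitive to a single added carbon. Nothing available explains the size of this step. As far as these compounds go, it remains open whether an ethyl group or an amine at the same position would give a similar step, and whether methyl on another carbon of this ring would do the same.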